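This account rests on a few compounds, and the source may have more. Where it says the series, first, only, none or still open, it means among the compounds named here.

Compound 1 `Cc1ncnc2c1c(-c1ccsc1)cn2[C@@H]1O[C@H](CO)[C@@H](O)[C@H]1O`: 460 nM
Compound 2 `CNc1ncnc2c1c(I)cn2[C@@H]1O[C@H](CO)[C@@H](O)[C@H]1O`: > 100000 nM

In a functional assay on HCT-116 cells (Homo sapiens), read by MTT assay, with a stated time of 72 h (a lower number here means a stronger inhibitor, a higher number a weaker inhibitor), compound 1 gives 460 nM, a measured number. Compound 2 gives > 100000 nM. That reading is a limit of the assay and not a number, so compound 2 has no exact place on the scale.

Compound 3 `Cc1ncnc2c1c(I)cn2[C@@H]1O[C@H](CO)[C@@H](O)[C@H]1O` differs from compound 2 in one place, with methyl in place of methylamino on an aromatic carbon. The change lies on the six-membered aromatic ring with 2 nitrogen, next to the ring nitrogen.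

For the measured compounds named here, no step between measured compounds gives this change a direct size. Going by the values given here, the only measured compound carrying the entering methyl is compound 1 at 460 nM, so a move towards stronger inhibition in this assay, beyond the scatter, is expected. That expectation is loose, and compound 3 could still remain at the limit.

The estimated step is an at least 33-fold lower number from compound 2 to compound 3 (1.52 log units; beyond the scatter). For compound 3 the expected value is 3000 nM, with an estimated range of 200 nM to 60000 nM.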

Compound 3, half-maximal inhibitory concentration: 4720 nM
Estimate against measurement, compound 3: 1.6-fold (0.20 log units) below; the measured number falls inside the stated range.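

In this assay, compound 2 stands at a limit of the assay and not at a number: the limit of > 100000 nM in this assay, at which 1 of the 3 values shown sits.

From the compounds shown here alone, with iodo held constant, methyl in place of methylamino on an aromatic carbon, on the six-membered aromatic ring with 2 nitrogen and next to the ring nitrogen, gives an at least 21-fold lower number from compound 2 to compound 3 (1.32 log units; beyond the scatter); this single change is enough to bring the series onto the measurable part of the scale, although the true size of the step remains unknown. With methyl held constant, iodo in place of thiophen-3-yl on an aromatic carbon gives a 10-fold higher number from compound 1 to compound 3 (1.01 log units; beyond the scatter), so the series also responds strongly in this assay to the group at this second site, and methyl alone does not set the reading.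

Going by these compounds, it remains open how a primary amine, a methoxy group or a longer chain such as ethyl would read at the position next to the ring nitrogen. On these data alone, it is also open whether the step from methylamino to methyl keeps its size with thiophen-3-yl on the core, and how a phenyl or a furan-3-yl group would compare with thiophen-3-yl.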